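The source may report more compounds than this note shows. Statements on the series, on what has been measured and on what is new or still open speak of the compounds shown alone.

Measured compounds:
- compound 1 `CC(C)=CCC/C(C)=C/CC/C(C)=C/C(=O)NC(=N)N`: 21000 nM
- compound 2 `CC(C)=CCC/C(C)=C/CC/C(C)=C/C(=O)NC(=N)NC(=O)C=C(C)C`: 15700 nM
- compound 3 `CC(C)=CCC/C(C)=C/C(=O)NC(=N)NC(=O)C=C(C)C`: 36200 nM

Among the measured compounds shown here, in a functional assay on U-373MG ATCC cells for inhibition, with U373 MG (Homo sapiens) as the target, read by MTT assay, with a stated time of 72 h (on this read-out higher numbers stand for weaker inhibition of growth and lower numbers for stronger inhibition of growth), compound 2 gives the lowest number of the three, though the step of a 1.3-fold lower number from compound 1 to compound 2 (0.13 log units; within the scatter) lies within the scatter and only the step of a 2.3-fold higher number from compound 2 to compound 3 (0.36 log units; beyond the scatter) lies beyond it. Compound 4 `CC(C)=CCC/C(C)=C/CC/C(C)=C/C(=O)NC(=N)NC(=O)/C=C(\C)CC/C=C(\C)CCC=C(C)C` differs from compound 2 by 3,7-dimethylocta-2,6-dien-1-yl in place of hydrogen on a saturated chain carbon bound to a double-bonded chain carbon. For the measured compounds named here, the one step that bears on chain length, a 2.3-fold higher number from compound 2 to compound 3 (0.36 log units; beyond the scatter), shows a shorter chain going with a higher number; the step of a 1.3-fold lower number from compound 1 to compound 2 (0.13 log units; within the scatter) shows that the acyl group itself changes little. A longer chain on the other acyl group is therefore expected to give a modest drop, a 1.6-fold lower number from compound 2 to compound 4 (0.20 log units; within the scatter). Compound 4 is estimated at 10000 nM, range 5000 nM to 25000 nM.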

Compound 4, concentration for 50% growth inhibition: 9200 nM
The estimate for compound 4 lay 1.1-fold (0.04 log units) above the measured number, within the range that was stated.
By their numbers in this assay, from the lowest: compounds 4, 2, 1 and 3 (each within the scatter of the next, the first and the last beyond it).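

The chain on the small acyl group, previously seen only as the bare 2-methylprop-1-en-1-yl carbonyl, can take 3,7-dimethylocta-2,6-dien-1-yl in place of hydrogen on a saturated chain carbon bound to a double-bonded chain carbon, and in this assay a 1.7-fold lower number from compound 2 to compound 4 (0.23 log units; within the scatter). This large addition therefore leaves the number within the scatter, so no gain can be claimed for it. No measurement bears on the reason for this result.

Open, as far as these compounds go, is whether an amine or a carboxylic acid in place of this chain would keep the number. Also open, from the compounds shown here alone, is how a longer chain here would read.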